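Chloro to hydroxy: one small swap in compound 3

The compounds below may be only part of what the source reports. "The series", "measured", "known", "first", "only" and "open" are said of these compounds alone.

Compound 1 `COc1cc(NC(C)CCCNC(=O)Nc2cccc(F)c2)c2ncccc2c1`: 22000 nM
Compound 2 `COc1cc(NC(C)CCCNC(=O)Nc2ccc(Cl)cc2)c2ncccc2c1`: 22000 nM

Both values come from a functional assay on MIA PaCa-2 cells (Homo sapiens) for inhibition, read by MTT assay, with a stated time of 72 h; a lower number here means a stronger inhibitor, a higher number a weaker inhibitor. There, compound 2 gives 22000 nM, level with compound 1. Compound 3 `COc1cc(NC(C)CCCNC(=O)Nc2ccc(O)cc2)c2ncccc2c1` differs from compound 2 by hydroxy in place of chloro on an aromatic carbon.

For the measured compounds named here, only one measured step bears on this change. It is no change at the digits printed from compound 1 to compound 2 (within the scatter), which puts 4-chlorophenyl in place of 3-fluorophenyl. That step shows that one swap of this kind left this assay unmoved, but it involves no hydroxy group, so it is only a loose guide. No step beyond the scatter is therefore expected, and no direction can be favoured with confidence. The expected change is a 1.1-fold higher number from compound 2 to compound 3 (0.06 log units; within the scatter). For compound 3 the estimate is 25000 nM, with an expected range of 9000 nM to 60000 nM.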

Compound 3, half-maximal inhibitory concentration: 57000 nM
Estimate against measurement, compound 3: 2.3-fold (0.36 log units) below; the range from low to high includes it.
By their numbers in this assay, from the lowest: compounds 1 and 2 (each within the scatter of the next); then compound 3.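

In this assay, the group on this aromatic carbon does matter: hydroxy in place of chloro gives a 2.6-fold higher number from compound 2 to compound 3 (0.41 log units; beyond the scatter) and moves the number beyond the scatter, whereas the earlier swap of one halogen-bearing phenyl group for another gave no change at the digits printed from compound 1 to compound 2 (within the scatter) and left it unmoved. The 4-hydroxyphenyl compound also separates from the 3-fluorophenyl compound, with a 2.6-fold higher number from compound 1 to compound 3 (0.41 log units; beyond the scatter) as a second modest step, so the shift appears against both halogen-bearing compounds. No measurement here accounts for this loss of strength.

As far as these compounds go, whether the higher number is particular to hydroxy, or would also appear with an amine or a carboxylic acid on the same carbon, remains open. It is also unknown whether a longer chain would change how much this group matters.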